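Replacing the Urea Aryl Group on an Inactive Sulfonamide

The source may report more compounds than this note shows. Statements on the series, on what has been measured and on what is new or still open speak of the compounds shown alone.

Of the compounds shown here, three of one series have so far been tested in a functional assay on HeLa cells (Homo sapiens) for inhibition, read by CCK-8 assay, with a stated time of 48 h; a lower number here means a stronger inhibitor, a higher number a weaker inhibitor. Compound 1 `Nc1ccc(Oc2ccccc2-c2ccc(S(=O)(=O)NCCNC(=O)Nc3ccc(Cl)cc3)s2)cc1` gives > 20000 nM, a limit of the assay rather than a number. Compound 2 `O=C(NCCNS(=O)(=O)c1ccc(-c2ccccc2Oc2ccc([N+](=O)[O-])c([N+](=O)[O-])c2)s1)Nc1ccc(Cl)cc1` likewise gives > 20000 nM, again a limit. Compound 3 `O=C(Nc1ccc([N+](=O)[O-])cc1)N1CCN(S(=O)(=O)c2sccc2-c2ccccc2Oc2ccc(O)c(O)c2)CC1` gives > 20000 nM, once more a limit. Going by the values given here, the one step between two measured compounds differing in a single place, a step that the two limits leave unreadable from compound 1 to compound 2, therefore cannot be read in size or direction. Compound 2 thus stands only at a limit, as do the other two values shown, and the limit of > 20000 nM in this assay, at which 3 of the 3 values shown sit, is the whole of the evidence.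

Compound 4 `COc1cccc(NC(=O)NCCNS(=O)(=O)c2ccc(-c3ccccc3Oc3ccc([N+](=O)[O-])c([N+](=O)[O-])c3)s2)c1` differs from compound 2 in one place: 3-methoxyphenyl in place of 4-chlorophenyl on an amide-type nitrogen. Among the compounds with values here, no measured step bears directly on this change, since the only step recorded is unreadable and concerns a different part of the molecule. Given that every measured compound sits at the limit, compound 4 is expected to remain there as well, with a step that the limit leaves unreadable from compound 2 to compound 4 expected to be no step beyond the scatter that could be read. The estimate for compound 4 in this assay is 30000 nM, with a range from 10000 nM to 100000 nM.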

Compound 4, half-maximal inhibitory concentration: > 20000 nM
Compound 4 gave a limit, no number; the forecaster's own chance of this, stated with the estimate: 80%; the middle value does not contradict the limit.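

In this assay compound 4 gives > 20000 nM, a limit and not a number. Compound 2 likewise stands at a limit, and the step between compound 2 and compound 4 cannot be read in size or direction. The compounds shown leave open whether any change to this series gives a readable value at all: the limit of > 20000 nM in this assay, at which 4 of the 4 values shown sit.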